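Exchanging the piperidin-1-yl Group of Compound 3

The source may report more compounds than this note shows. Statements on the series, on what has been measured and on what is new or still open speak of the compounds shown alone.

Of the compounds shown here, three sharing one core have been tested in an ADME assay on Vero cells (Chlorocebus sabaeus) for cytotoxicity, read by MTT assay, with a stated time of 72 h; on this read-out higher numbers stand for weaker inhibition and lower numbers for stronger inhibition. For the measured compounds named here, compound 1 `O=C(O)c1cn(C2CC2)c2nc(N3CCN(C(c4ccccc4)c4ccc(Cl)cc4)CC3)c([N+](=O)[O-])cc2c1=O` gives 112000 nM, the only actual number among them. Compound 2 `CC1CN(c2nc3c(cc2[N+](=O)[O-])c(=O)c(C(=O)O)cn3C2CC2)CC(C)O1` stands only at a limit, > 160000 nM. Compound 3 `O=C(O)c1cn(C2CC2)c2nc(N3CCC(N4CCCCC4)CC3)c([N+](=O)[O-])cc2c1=O` likewise stands only at a limit, > 141000 nM. Compound 4 `O=C(O)c1cn(C2CC2)c2nc(N3CCC(n4c(=O)[nH]c5cc(Cl)ccc54)CC3)c([N+](=O)[O-])cc2c1=O` differs from compound 3 on a saturated ring carbon of a six-membered non-aromatic ring with 1 nitrogen: a group of 11 heavy atoms (7 carbon, 2 nitrogen, 1 oxygen, 1 chlorine; one five-membered aromatic ring with 2 hetero atoms, one six-membered aromatic ring of carbon only) in place of a group of 6 heavy atoms (5 carbon, 1 nitrogen; one six-membered non-aromatic ring with 1 hetero atom), on a saturated ring carbon. Going by the values given here, no measured pair shows such a change, so only a small step towards stronger inhibition is expected in this assay, hardly beyond the scatter. That expectation rests on compound 1 at 112000 nM. The expected step is an at least 1.4-fold lower number from compound 3 to compound 4 (0.14 log units; that floor lies within the scatter). For compound 4 the estimated value is 100000 nM, within a range of 40000 nM to 200000 nM.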

Compound 4, half-maximal inhibitory concentration: 55500 nM
Compound 4: the middle estimate sits 1.8-fold (0.26 log units) above what was measured; the measured number falls inside the stated range.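

In this assay, exchanging the piperidin-1-yl group on this saturated ring carbon for the larger group of compound 4 gives a readable shift, an at least 2.5-fold lower number from compound 3 to compound 4 (0.40 log units; beyond the scatter). For the compounds shown here, this is the first step between measured compounds at this position, and it gives compound 4 an actual number where compound 3 has none. The step is only a minimum because compound 3 stands at a limit: the limit of > 141000 nM in this assay, at which 1 of the 4 values shown sits.

From the compounds shown here alone, it remains open whether the chlorine of the entering group contributes to this shift. Going by these compounds, it also remains open how a dimethylamino group or a carboxylic acid on the same ring carbon would read.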